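Methyl to methoxy step from compound 3

A few compounds are considered here, and "the series" means these few. Any claim that something is new, unique, unknown or untested is made for them only; others in the source may bear on it.

Measured in a functional assay on RS4-11 cells (Homo sapiens) for inhibition, read by CCK-8 assay, with a stated time of 48 h, tested at 20 uM (a lower number here means less inhibition of growth, a higher number more inhibition of growth at the concentration tested), for three compounds
- compound 1 `Cc1ccc(S(=O)(=O)Oc2ccccc2/C=C(\C#N)C(=O)Nc2nnc(C)s2)cc1` gives 33%
- compound 2 `COc1ccc(S(=O)(=O)Oc2ccccc2/C=C(\C#N)C(=O)Nc2nnc(-c3cccs3)s2)cc1` gives 76%
- compound 3 `COc1ccc(Cc2nnc(NC(=O)/C(C#N)=C/c3ccccc3OS(=O)(=O)c3ccc(C)cc3)s2)cc1` gives 70%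

Compound 3 lies within the scatter of compound 2 and beyond the scatter above compound 1. Compound 4 `COc1ccc(Cc2nnc(NC(=O)/C(C#N)=C/c3ccccc3OS(=O)(=O)c3ccc(OC)cc3)s2)cc1` changes it by methoxy in place of methyl on an aromatic carbon, para to a large group methoxy in place of methyl on an aromatic carbon and so turns 4-methylphenyl into 4-methoxyphenyl. Going by the values given here, the only measured step, a number 37 percentage points higher from compound 1 to compound 3 (beyond the scatter), lies elsewhere in the molecule and says nothing direct about this place. Compound 2 carries the 4-methoxyphenyl sulfonyl group but differs from compound 3 in more than one place, and their values lie within the scatter. Expected is a number 2 percentage points higher from compound 3 to compound 4 (within the scatter), with no shift beyond the scatter in either direction. For compound 4 the estimated value is 72%, with an expected range from 58% to 85%.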

Compound 4, percent growth inhibition at one concentration: 78%
Estimate against measurement, compound 4: 6 percentage points below; the measured number falls inside the stated range.
By their numbers in this assay, from the lowest: compound 1; then compounds 3, 2 and 4 (each within the scatter of the next).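

In this assay, the change from (4-methylphenyl)sulfonyl to (4-methoxyphenyl)sulfonyl can now be read directly, giving a number 8 percentage points higher from compound 3 to compound 4 (within the scatter), so methoxy in place of methyl on this aromatic carbon has no effect separable from the scatter. With the 4-methoxyphenyl group held constant, 4-methoxybenzyl in place of thiophen-2-yl gives a number 2 percentage points higher from compound 2 to compound 4 (within the scatter), so these two groups are not distinguished here either. No evidence bears on the reason for either step.

Open, as far as these compounds go, is whether an amine or a carboxylic acid on this aromatic carbon would give a step beyond the scatter. Readings at one concentration also leave open how compound 2 and compound 4 compare across a range of concentrations.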